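Removing the formyl group from a triazole sulfonamide

The source may hold more compounds than are shown below. What is called first, only, known or untested is meant among the compounds shown, and "the series" means these compounds.

Compound 1 `Cc1ccccc1OCc1cn(-c2ccc(S(=O)(=O)N3CCc4ccccc4C3)cc2)nn1` and compound 2 `O=Cc1ccc(OCc2cn(-c3ccc(S(=O)(=O)N4CCc5ccccc5C4)cc3)nn2)cc1` share one core and differ only in the aryl ether. In an ADME assay on Vero cells (Chlorocebus sabaeus) for cytotoxicity, with a stated time of 4 days (on this read-out lower numbers stand for stronger inhibition and higher numbers for weaker inhibition), compound 1 gives only a limit of the assay, > 50 ug/mL. Compound 2 likewise gives only a limit in this assay, > 50 ug/mL. The step that the two limits leave unreadable from compound 1 to compound 2 therefore has no readable size. Compound 2 thus stands at the limit of > 50 ug/mL in this assay, at which 2 of the 2 values shown sit, with no number of its own to place it. Compound 3 `O=S(=O)(c1ccc(-n2cc(COc3ccccc3)nn2)cc1)N1CCc2ccccc2C1` differs from compound 2 by hydrogen in place of formyl on an aromatic carbon. For the measured compounds named here, the single measured step, a step that the two limits leave unreadable from compound 1 to compound 2, alters the same aryl ether and left both ends at the limit, so it offers no size to carry over. Compound 3 is accordingly expected to show no step beyond the scatter, a step that the limit leaves unreadable from compound 2 to compound 3, and its value in this assay is estimated at 80 ug/mL, with a range from 40 ug/mL to 200 ug/mL.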

Compound 3, half-maximal inhibitory concentration: > 50 ug/mL
Compound 3: a limit, no number; the forecaster's own chance of this, stated with the estimate: 85%; the middle value is on the limit's open side.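

In this assay compound 3 also gives only a limit (> 50 ug/mL). No step among compound 1, compound 2 and compound 3 can be read, as all three sit at that limit: the limit of > 50 ug/mL in this assay, at which 3 of the 3 values shown sit.

The compounds shown leave open how far each lies from that limit, and whether changing the aryl ether alters cytotoxicity at all.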